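This account rests on a few compounds, and the source may have more. Where it says the series, first, only, none or still open, it means among the compounds named here.

Measured so far:
compound 1 `CC1COC2(C)Oc3c(c4c(c5c3CC3C(C)COC3(C)O5)CC3C(C)COC3(C)O4)CC12`: 11000 nM
compound 2 `COc1cc2c(c3c1C[C@@H]1[C@@H](C)CO[C@]1(C)O3)C[C@@H]1[C@@H](C)CO[C@]1(C)O2`: 33000 nM
compound 3 `CC1COC2(C)Oc3cc(O)c4c(c3CC12)OC1(C)OCC(C)C1C4`: 41000 nM

Of the compounds shown here, three built on a shared core have been tested in a functional assay on aorta (Rattus norvegicus, strain Sprague-Dawley) for inhibition; a lower number here means that less compound is needed, a higher number that more compound is needed for the effect. Compound 1 gives 11000 nM, compound 2 gives 33000 nM, and compound 3 gives 41000 nM. Among these three numbers compound 2 holds the second highest; its value and that of compound 3 lie within the usual scatter of each other, so nothing separates the two, whereas compound 1 shows a number lower than that of compound 2 by a margin beyond the scatter. For the measured compounds named here, no pair of the measured compounds differs in only one place, so no single measured step is available for guidance.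

The unmeasured compound 4 `C[C@H]1CO[C@]2(C)Oc3cc(OC/C=C/c4ccccc4)c4c(c3C[C@H]12)O[C@@]1(C)OC[C@H](C)[C@H]1C4` derives from compound 2 through one change: 2-phenylethenyl in place of hydrogen on a saturated chain carbon bound to an oxygen on an aromatic ring. Going by the values given here, with no comparable measured step, there is no firm basis for the direction or size of the effect in this assay. Given the spread of the three numbers, a step of moderate size in either direction would not surprise, and a modest drop in the number is expected, corresponding to an expected step of a 2.2-fold lower number from compound 2 to compound 4 (0.34 log units; beyond the scatter). Compound 4 is accordingly estimated at 15000 nM, with an expected range from 4000 nM to 50000 nM.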

Compound 4, half-maximal effective concentration: > 200000 nM
Compound 4: a limit, no number; the forecaster's own chance of this, stated with the estimate: 15%; at least 13-fold (1.12 log units) between middle value and limit.
By their numbers in this assay, from the lowest: compound 1; then compounds 2 and 3 (each within the scatter of the next). At a limit, above all of these: compound 4.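

In this assay compound 4 gives no number, only a limit of the assay: the limit of > 200000 nM in this assay, at which 1 of the 4 values shown sits. For the compounds shown here, the exchange of methoxy for (3-phenylprop-2-en-1-yl)oxy on the shared core gives an at least 6.0-fold higher number from compound 2 to compound 4 (0.78 log units; beyond the scatter), and this is the first change in a single place that can be read, as the earlier compounds offered no such pair. It shows that the group carried by the oxygen on an aromatic ring matters in this assay, and that adding 2-phenylethenyl on the saturated chain carbon bound to that oxygen moves the number up, not down.

The compounds shown leave open whether this step belongs to the aromatic ring of the new group, to its double bond or to the length of the chain alone, and how a plain propyl chain or a chain ending in an amine or a carboxylic acid would read at this place. Nor do they tell whether any group on this oxygen can bring the number below that of compound 2.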